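Chloro to fluoro swap on the fused ring

The source may hold more compounds than are shown below. What is called first, only, known or untested is meant among the compounds shown, and "the series" means these compounds.

Compound 1 `CC1(C)CC(NC(=S)NCc2ccccc2)c2cc(F)ccc2O1` and compound 2 `CC1(C)CC(NC(=S)NCc2ccccc2)c2cc(Cl)ccc2O1` share the benzyl thiourea arm and differ only in the halogen on the fused ring. In a functional assay on T98G cells (Homo sapiens) for inhibition, read by MTT assay, with a stated time of 72 h (on this read-out lower numbers stand for stronger inhibition and higher numbers for weaker inhibition), compound 1 gives 40000 nM, while compound 2 gives 99000 nM. The step of a 2.5-fold lower number from compound 2 to compound 1 (0.39 log units; beyond the scatter) comes from the change (fluoro in place of chloro on an aromatic carbon).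

Compound 3 `CC1(C)CC(NC(=S)Nc2cccc([N+](=O)[O-])c2)c2cc(Cl)ccc2O1` carries a nitrophenyl thiourea arm in place of the benzyl arm. In this assay compound 3 gives 4000 nM, the lowest of the three numbers. The difference between the cores of compound 2 and compound 3 is not broken down here; their two values simply show a much lower number for compound 3.

Compound 4 `CC1(C)CC(NC(=S)Nc2cccc([N+](=O)[O-])c2)c2cc(F)ccc2O1` has not been measured in this assay. It arises from compound 3 by fluoro in place of chloro on an aromatic carbon, the same change as that from compound 2 to compound 1, and the place is described in the same words. For the measured compounds named here, only one earlier instance of this change is available, so any expectation rests on a single step. For compound 4 the step of a 1.8-fold lower number from compound 3 to compound 4 (0.26 log units; within the scatter) is expected, of about the same size as a 2.5-fold lower number from compound 2 to compound 1 (0.39 log units; beyond the scatter), because compound 1 gives 40000 nM where compound 2 gives 99000 nM. Whether the change carries over from the benzyl arm to the nitrophenyl arm is not shown by any measured pair, so the range is kept wide. In this assay compound 4 is estimated at 2200 nM, with the likely range 900 nM to 6000 nM.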

Compound 4, half-maximal inhibitory concentration: 9000 nM
Compound 4: middle estimate off by 4.1-fold (0.61 log units), on the low side, and the stated range ends below it.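

On the nitrophenyl thiourea arm, fluoro in place of chloro on an aromatic carbon gives a 2.3-fold higher number from compound 3 to compound 4 (0.35 log units; beyond the scatter) in this assay. Set beside the same swap on the benzyl thiourea arm, the step runs the opposite way, and the two steps do not agree: the same change on two cores in this assay, a 2.5-fold lower number (0.39 log units; beyond the scatter) from compound 2 to compound 1 and a 2.3-fold higher number (0.35 log units; beyond the scatter) from compound 3 to compound 4, 5.6-fold (0.75 log units) apart, beyond the scatter of two such steps. For the compounds shown here, in this series, the swap therefore does not carry from one core to the other as a fixed increment, or even with a fixed direction, although this rests on only two pairs and does not show which feature of the thiourea arm sets the direction or how the swap would run on a third arm.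

The compounds shown hold only fluoro and chloro on the fused ring, and only a benzyl or nitrophenyl group on the thiourea, so it remains open how a bromo or methoxy group at the same aromatic carbon would behave on either core. Also open, as far as these compounds go, is which of the two directions, if either, would appear with an aminophenyl group or a longer chain such as phenethyl on the thiourea, and whether the reversal holds outside this assay.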